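The source may report more compounds than this note shows. Statements on the series, on what has been measured and on what is new or still open speak of the compounds shown alone.

Compound 1, `O=C(COc1ccc2c(=O)cc(-c3ccccc3)oc2c1)Nc1ccccc1`, was tested in a functional assay on MT2 cells (Homo sapiens) for antiproliferative activity, read by MTT assay, with a stated time of 72 h; on this read-out higher numbers stand for weaker inhibition of growth and lower numbers for stronger inhibition of growth. In this assay compound 1 gives only a limit, > 10000 nM, and not a number. Compound 2, `O=C(COc1ccc2c(=O)cc(-c3ccccc3)oc2c1)Nc1ccc(F)cc1`, carries one change relative to compound 1: fluoro in place of hydrogen on an aromatic carbon. In this assay compound 2 gives 6410 nM. The step measured was an at least 1.5-fold lower number from compound 1 to compound 2 (0.19 log units; that floor lies within the scatter). Its size rests on (the limit of > 10000 nM in this assay, at which 2 of the 3 values shown sit), so only a floor for the step is known, and that floor lies within the usual scatter.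

Compound 3, `O=C(COc1ccc2c(=O)c(-c3ccccc3)coc2c1)Nc1ccccc1`, is built from the same atoms as compound 1, joined differently; the difference between the two cores is not broken down here. In this assay compound 3 gives only a limit, > 10000 nM, and not a number.

Compound 4, `O=C(COc1ccc2c(=O)c(-c3ccccc3)coc2c1)Nc1ccc(F)cc1`, is not yet measured. It differs from compound 3 by fluoro in place of hydrogen on an aromatic carbon, the same change as from compound 1 to compound 2, and the surroundings of the place are described in the same words for both pairs. Beside the earlier step, the step from compound 3 to compound 4 in this assay is expected to be an at least 1.2-fold lower number from compound 3 to compound 4 (0.09 log units; that floor lies within the scatter). Within the data shown here, this expectation rests on compound 2, the one compound that gives a number in this assay, 6410 nM, while the pair sharing the core of compound 3 is otherwise without a number. For compound 4 the value expected in this assay is 8000 nM, with a likely range from 3500 nM to 20000 nM.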

Compound 4, concentration for 50% growth inhibition: 2500 nM
Compound 4: the middle estimate sits 3.2-fold (0.51 log units) above what was measured, and the stated range ends above it.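

Carried to the second core, the change from anilino to (4-fluorophenyl)amino gives in this assay an at least 4.0-fold lower number from compound 3 to compound 4 (0.60 log units; beyond the scatter), so the number falls in the same direction on both cores, and this floor is clear of the usual scatter. This shows that the change can be carried from one core to the other without losing its direction, although two pairs are too few to make a general rule, and the two steps can be set side by side only loosely: the same change on two cores in this assay, an at least 1.5-fold lower number (0.19 log units; that floor lies within the scatter) from compound 1 to compound 2 and an at least 4.0-fold lower number (0.60 log units; beyond the scatter) from compound 3 to compound 4; the limit leaves it open whether they differ Compound 1 and compound 3 each give only a limit, so neither step has a known full size, and nothing here shows that fluoro does more on one core than on the other: the limit of > 10000 nM in this assay, at which 2 of the 4 values shown sit.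

The compounds shown leave open whether other groups in the same place on the ring, such as chloro, methoxy or a carboxylic acid, would lower the number as fluoro does. They also leave open whether fluoro elsewhere on that ring would do the same, and whether the step would hold on a third core.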